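The source may report more compounds than this note shows. Statements on the series, on what has been measured and on what is new or still open speak of the compounds shown alone.

Compound 1 `Cc1ccccc1C(=O)NNC(=O)c1ccc(NS(=O)(=O)c2cnc(O)nc2O)cc1` was tested in a functional assay on A549 cells (Homo sapiens) for antiproliferative activity, read by MTT assay, with a stated time of 24 h (on this read-out higher numbers stand for weaker inhibition and lower numbers for stronger inhibition), where compound 1 gives 15100 nM. Compound 2 `Cc1ccc(C(=O)NNC(=O)c2ccc(NS(=O)(=O)c3cnc(O)nc3O)cc2)cc1` carries the change 4-methylphenyl in place of 2-methylphenyl on a carbonyl carbon and in this assay compound 2 gives 15900 nM, so that the step is a 1.1-fold higher number from compound 1 to compound 2 (0.02 log units; within the scatter). Compound 3 `Cc1ccccc1C(=O)NNC(=O)c1cccc(NS(=O)(=O)c2cnc(O)nc2O)c1` has a core that differs from that of compound 1, but how the two cores differ is not broken down here; in this assay compound 3 gives 8010 nM. Compound 4 `Cc1ccc(C(=O)NNC(=O)c2cccc(NS(=O)(=O)c3cnc(O)nc3O)c2)cc1` has not yet been measured and differs from compound 3 by 4-methylphenyl in place of 2-methylphenyl on a carbonyl carbon, the same change made from compound 1 to compound 2. Because that earlier step was a 1.1-fold higher number from compound 1 to compound 2 (0.02 log units; within the scatter), the step from compound 3 to compound 4 in this assay is expected to be about as small, a 1.1-fold higher number from compound 3 to compound 4 (0.03 log units; within the scatter). Compound 4 is therefore estimated at 8500 nM, between 4000 nM and 18000 nM.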

Compound 4, half-maximal inhibitory concentration: > 20000 nM
Compound 4: only a limit was reported (the forecaster's own chance of this, stated with the estimate: 5%); middle value at least 2.3-fold (0.37 log units) away from the limit.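

In this assay compound 4 gives > 20000 nM, which is a limit of the assay and not a number. Putting 4-methylphenyl in place of 2-methylphenyl gave an at least 2.4-fold higher number from compound 3 to compound 4 (0.39 log units; beyond the scatter), whereas the same change on the other core gave a 1.1-fold higher number from compound 1 to compound 2 (0.02 log units; within the scatter). The change therefore shows a step beyond the scatter on one core and within it on the other, but this does not show that the size of the change depends on the core: the same change on two cores in this assay, a 1.1-fold higher number (0.02 log units; within the scatter) from compound 1 to compound 2 and an at least 2.4-fold higher number (0.39 log units; beyond the scatter) from compound 3 to compound 4; the limit leaves it open whether they differ.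

On these data alone, the true value of compound 4 remains open. Also open, as far as these compounds go, is how either core would respond if the methyl group gave way to a chlorine atom or a methoxy group, or if the phenyl ring carried no methyl group at all.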